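A few compounds are considered here, and "the series" means these few. Any claim that something is new, unique, unknown or untested is made for them only; others in the source may bear on it.

Measured so far in an ADME assay on HCT-116 cells (Homo sapiens) for cytotoxicity, read by CellTiter-Glo, with a stated time of 72 h; a lower number here means a stronger inhibitor, a higher number a weaker inhibitor:
- compound 1 `CC1CCN(C2CCN(S(=O)(=O)c3cn(C)cn3)CC2)CC1` — > 10000 nM
- compound 2 `Cc1cc(C)c(S(=O)(=O)N2CCC(N3CCC(O)CC3)CC2)c(C)c1` — > 5000 nM
- compound 3 `Cc1cc(C)c(S(=O)(=O)N2CCC(C(=O)N3CCC(C)CC3)CC2)c(C)c1` — > 5000 nM

All three values are limits of this assay, not numbers. Compound 1 sits at the limit of > 10000 nM in this assay, at which 1 of the 3 values shown sits. Compound 2 sits at the limit of > 5000 nM in this assay, at which 2 of the 3 values shown sit, and compound 3 sits at that same limit. Within the data shown here, the one step between neighbours, a step that the two limits leave unreadable from compound 2 to compound 3, therefore says nothing readable about size or direction.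

Compound 4 `CC1CCN(C2CCN(S(=O)(=O)c3ccc(C#N)cc3)CC2)CC1` is the next variation. Its change from compound 1: 4-cyanophenyl in place of 1-methyl-1H-imidazol-4-yl on a sulfonyl sulfur. Among the measured compounds shown here, no measured step touches the group on the sulfonyl sulfur, so there is no readable precedent for this change; the only evidence is that compound 1 itself gives a limit and that every other compound does the same.

The expectation for compound 4 is therefore another limit rather than a number. Compound 4 is estimated at 20000 nM in this assay, within 5000 nM to 80000 nM. The step this estimate means, a step that the limit leaves unreadable from compound 1 to compound 4, is expected to be no change beyond the scatter.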

Compound 4, half-maximal inhibitory concentration: > 5000 nM
Compound 4: only a limit was reported; the forecaster's own chance of this, stated with the estimate: 85%; the middle value is on the limit's open side.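

In this assay compound 4 gives > 5000 nM, a limit and not a number. Among these compounds, compound 1 also gives only a limit, and no step between compound 1 and compound 4 can be read. The compounds shown leave open whether the group on the sulfonyl sulfur moves the value at all.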